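Chloro for Methoxy on the Shared Core

The source may hold more compounds than are shown below. What is called first, only, known or untested is meant among the compounds shown, and "the series" means these compounds.

Of the compounds shown here, two have so far been tested in a functional assay on SK-OV-3 cells (Homo sapiens) for inhibition, read by sulforhodamine B assay, with a stated time of 48 h; on this read-out lower numbers stand for stronger inhibition of growth and higher numbers for weaker inhibition of growth. Compound 1 `N=C(N)c1ccc(-c2ccc(-c3cc(Cl)cc(Cl)c3)s2)s1` gives 3620 nM in this assay. Compound 2 `COc1ccc(-c2ccc(-c3ccc(C(=N)N)o3)o2)cc1` gives 5630 nM, the higher of the two numbers, though its gap to compound 1 lies within the scatter, so the two cannot be told apart. Compound 3 `N=C(N)c1ccc(-c2ccc(-c3ccc(Cl)cc3)o2)o1` is not yet measured; it differs from compound 2 in one place: chloro in place of methoxy on an aromatic carbon. For the measured compounds named here, no measured pair shows this change, so nothing fixes its size. The step of a 1.3-fold lower number from compound 2 to compound 3 (0.10 log units; within the scatter) is expected to stay within the scatter. The estimate for compound 3 is 4500 nM, ranging from 1500 nM to 13000 nM.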

Compound 3, concentration for 50% growth inhibition: 1790 nM
The estimate for compound 3 lay 2.5-fold (0.40 log units) above the measured number; the range from low to high includes it.
By their numbers in this assay, from the lowest: compound 3; then compounds 1 and 2 (each within the scatter of the next).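

In this assay, chloro in place of methoxy on this aromatic carbon, para to a large group, gives a 3.1-fold lower number from compound 2 to compound 3 (0.50 log units; beyond the scatter), so the group at this position does affect growth inhibition. Compound 1 and compound 2 differ in more than one place, so they could not show this. On these data alone, it remains open whether fluoro, an amine or a carboxylic acid at this position would lower the number further or raise it again. Nothing available explains the size of this step.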